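The source may hold more compounds than are shown below. What is called first, only, known or untested is meant among the compounds shown, and "the series" means these compounds.

Measured in an assay on HEK cells for inhibition of Tryptophan 2,3-dioxygenase (Homo sapiens); a higher number here means a weaker inhibitor, a lower number a stronger inhibitor:
Compound 1, `O=C(Nc1ccc(C(F)(F)F)cc1)C(=O)N1CCC(c2ccnc3ccc(F)cc23)CC1`, gives 9500 nM.
Compound 2, `CC1(C)CN(C(=O)C(=O)Nc2ccc(Cl)cc2)CCC1c1ccnc2ccc(F)cc12`, gives 4500 nM.
Compound 3, `O=C(Nc1ccc(Cl)cc1)C(=O)N1CC[C@H](c2ccnc3ccc(F)cc23)[C@@H](O)C1`, gives 14000 nM.

Compound 3 sits at the high end of these three numbers. Its number and that of compound 1 lie within the usual scatter of each other, so nothing separates them; compound 2, by contrast, lies beyond the scatter lower than compound 3.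

The next compound, compound 4, is `O=C(Nc1ccc(Cl)cc1)C(=O)N1CC[C@@H](c2ccnc3ccc(F)cc23)[C@@H](O)C1`. Its change from compound 3 is this: the two compounds have the same atoms and bonds and differ only in configuration as drawn: 1 of 2 stereo elements differ; a stereocentre at a saturated ring carbon is drawn R in compound 3 and S in compound 4. Among the compounds with values here, no pair of measured compounds shows what such a change of configuration does in this assay, so no direction can be read from the data. The expectation is a step of a 1.4-fold lower number from compound 3 to compound 4 (0.15 log units; within the scatter), that is, no step beyond the scatter. Compound 4 is therefore estimated at 10000 nM, with a range from 3000 nM to 35000 nM.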

Compound 4, half-maximal inhibitory concentration: 37000 nM
Estimate against measurement, compound 4: 3.7-fold (0.57 log units) below, and the stated range ends below it.
By their numbers in this assay, from the lowest: compound 2; then compounds 1 and 3 (each within the scatter of the next); then compound 4.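

In this assay the change at this one stereocentre gives a 2.6-fold higher number from compound 3 to compound 4 (0.42 log units; beyond the scatter), the first measured sign that configuration at this saturated ring carbon matters, with the form drawn S the weaker inhibitor of the pair. The step can be assigned to configuration alone for one reason: the fact that compounds 3 and 4 differ only in the configuration as drawn.

From the compounds shown here alone, it remains open whether the same preference holds when the other stereocentre is inverted. Also open, going by these compounds, is whether configuration at this carbon would matter as much if an amine or a methoxy group replaced the hydroxyl.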